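The source may hold more compounds than are shown below. What is called first, only, known or untested is meant among the compounds shown, and "the series" means these compounds.

Compound 1 `COc1cc(OC)c(C(=O)/C=C/c2ccc(Cl)cc2)c(OC)c1` gives 39%
Compound 2 `COc1cccc(/C=C/C(=O)c2c(O)cc(OC)cc2OC)c1` gives 31%
Compound 3 `COc1cc(O)c(C(=O)/C=C/c2ccccc2SC)c(OC)c1` gives 50%

Of the compounds shown here, three have been tested in a functional assay on Caco-2 cells (Homo sapiens), read by fluorescence and BrdU incorporation, with a stated time of 48 h, tested at 10 uM; a lower number here means a stronger effect, a higher number a weaker effect of the compound at the concentration tested. Among them compound 1 stands second highest of the three numbers. Its nearest neighbour is compound 2, whose number is lower by a gap that lies within the usual scatter of this assay, so the two cannot be told apart. The furthest is compound 3, whose number lies higher than that of compound 1 by a gap beyond the scatter, which marks compound 3 as the weaker of the two at the concentration tested.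

Compound 4 `COc1cc(OC)c(C(=O)/C=C/c2ccc(F)cc2)c(OC)c1` has not yet been measured in this assay . It differs from compound 1 in a single place: fluoro in place of chloro on an aromatic carbon. For the measured compounds named here, no pair of measured compounds differs in one place, so no measured step speaks to this exchange directly. The shared core and the rest of the substitution are unchanged, and the exchange of one halogen for another on the same aromatic carbon is a small one. The step from compound 1 to compound 4 is therefore expected to stay within the scatter, with at most a slight drift towards a higher number, giving an expected a number 6 percentage points higher from compound 1 to compound 4 (within the scatter). For compound 4 the estimate in this assay is 45%, with a range from 25% to 65%.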

Compound 4, a percentage reported as activity, at one concentration (the size of the read-out at that concentration, not a potency): 39%
For compound 4 the middle estimate is 6 percentage points above the measured one, and the stated range covers the measured number.
By their numbers in this assay, from the lowest: compounds 2, 1 and 4 (each within the scatter of the next); then compound 3.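

In this assay, for the compounds shown here, the exchange of chloro for fluoro on an aromatic carbon para to a large group gives the first single-place step in this set, with no change at the digits printed from compound 1 to compound 4 (within the scatter). Going by these compounds alone, at this position on the shared core, going from 4-chlorophenyl to 4-fluorophenyl therefore leaves the read-out at the concentration tested without a change that can be distinguished, something the earlier compounds, none of which formed a single-place pair, could not show. No measured information is available here to explain this result.

The compounds shown leave open whether an amine or a carboxylic acid on this same aromatic carbon would also keep the number within the scatter of compound 1 or would move it beyond the scatter. They also leave open whether fluoro in place of chloro would give the same result on another core, as this finding rests on a single pair of compounds.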